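The source may hold more compounds than are shown below. What is called first, only, known or untested is meant among the compounds shown, and "the series" means these compounds.

Compound 1 `Oc1ccc(/C=C/c2ccccc2O)cc1`, compound 2 `COc1cccc(/C=C/c2ccccc2O)c1` and compound 3 `Nc1ccc(/C=C/c2ccccc2O)cc1` share a common core and were tested in a functional assay on HT-29 cells (Homo sapiens) for inhibition, read by MTT assay, with a stated time of 2 days; on this read-out higher numbers stand for weaker inhibition and lower numbers for stronger inhibition. Compound 1 gives 22 ug/mL, compound 2 gives 26 ug/mL and compound 3 gives 37 ug/mL, and these three numbers all fall within the usual scatter of one another. How the cores of compound 1 and compound 2 differ is not broken down here. Compound 3 arises from compound 1 by a single change, (amino in place of hydroxy on an aromatic carbon), made para to a group of 9 heavy atoms; this gave a 1.7-fold higher number from compound 1 to compound 3 (0.23 log units; within the scatter). Compound 4 `COc1cccc(/C=C/c2ccccc2N)c1`, not yet measured, arises from compound 2 by the same kind of change, (amino in place of hydroxy on an aromatic carbon), here made ortho to a large group. Because the earlier step of a 1.7-fold higher number from compound 1 to compound 3 (0.23 log units; within the scatter) stayed within the scatter, a step of similar size is expected, a 1.5-fold higher number from compound 2 to compound 4 (0.19 log units; within the scatter). Compound 4 is therefore estimated at 40 ug/mL, most likely between 20 ug/mL and 80 ug/mL in this assay.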

Compound 4, half-maximal inhibitory concentration: 21.2 ug/mL
Compound 4: middle estimate off by 1.9-fold (0.28 log units), on the high side, within the range that was stated.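

Putting amino in place of hydroxy gave a 1.2-fold lower number from compound 2 to compound 4 (0.09 log units; within the scatter) in this assay. Set beside the same change on the other core, the two steps do not differ by more than ordinary scatter: the same change on two cores in this assay, a 1.7-fold higher number (0.23 log units; within the scatter) from compound 1 to compound 3 and a 1.2-fold lower number (0.09 log units; within the scatter) from compound 2 to compound 4, 2.1-fold (0.31 log units) apart, within the scatter of two such steps. On these two pairs, then, the change leaves the number within the scatter on both cores, but two small steps show neither a real effect of the change nor that the same would hold on other cores.

The compounds shown leave open how a carboxylic acid or a nitrile would behave in place of the hydroxy or the amino. They also leave open whether this change would give a step beyond the scatter on any other core.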